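This account rests on a few compounds, and the source may have more. Where it says the series, first, only, none or still open, it means among the compounds named here.

Notes on the series. Compound 3 `COC(=O)C(=O)CNC1=CS(=O)(=O)O[C@@]12[C@@H](CO[Si](C)(C)C(C)(C)C)O[C@@H](n1cc(C)c(=O)n(C)c1=O)[C@@H]2O[Si](C)(C)C(C)(C)C` stands in a functional assay on HEL cells (Homo sapiens) for cytotoxicity, read by microscopy (a lower number here means that less compound is tolerated, a higher number that more compound is tolerated), only at a limit of the assay, > 400000 nM, not at a number. Compound 2 `COC(=O)CNC1=CS(=O)(=O)O[C@@]12[C@@H](CO[Si](C)(C)C(C)(C)C)O[C@@H](n1cc(C)c(=O)n(C)c1=O)[C@@H]2O[Si](C)(C)C(C)(C)C` likewise reaches only a limit in this assay, >= 400000 nM. Compound 1 `CC(=O)NC1=CS(=O)(=O)O[C@@]12[C@@H](CO[Si](C)(C)C(C)(C)C)O[C@@H](n1cc(C)c(=O)n(C)c1=O)[C@@H]2O[Si](C)(C)C(C)(C)C` gives in this assay a limit as well, >= 80000 nM. The steps a step that the two limits leave unreadable from compound 1 to compound 2, a step that the two limits leave unreadable from compound 1 to compound 3 and a step that the two limits leave unreadable from compound 2 to compound 3 have no readable size because of the limit of > 400000 nM in this assay, at which 1 of the 3 values shown sits, the limit of >= 400000 nM in this assay, at which 1 of the 3 values shown sits, and the limit of >= 80000 nM in this assay, at which 1 of the 3 values shown sits, bound each end. Compound 4 `CCNC(=O)NC1=CS(=O)(=O)O[C@@]12[C@@H](CO[Si](C)(C)C(C)(C)C)O[C@@H](n1cc(C)c(=O)n(C)c1=O)[C@@H]2O[Si](C)(C)C(C)(C)C` carries ethylcarbamoyl in place of ((methoxycarbonyl)carbonyl)methyl on an amine nitrogen. Going by the values given here, no measured step shows a size, so nothing beyond the scatter is expected in this assay for this change. Compound 4 is therefore expected to sit at a limit too, estimated at 400000 nM, range 80000 nM to 400000 nM, with the step of a number no higher from compound 3 to compound 4 (the limit leaves the size open) expected.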

Compound 4, minimum cytotoxic concentration: >= 3200 nM
Compound 4 gave a limit, no number (the forecaster's own chance of this, stated with the estimate: 85%); the middle value lies beyond the limit too.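

Compound 4 reaches only a limit, >= 3200 nM, in this assay, so its steps from compound 1, compound 2 and compound 3 cannot be read. The compounds shown leave open whether ethylcarbamoyl changes tolerance in this assay at all.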